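The compounds below may be only part of what the source reports. "The series", "measured", "known", "first", "only" and "open" are said of these compounds alone.

Of the compounds shown here, three sharing one core have been measured in an ADME assay on Vero cells (Chlorocebus sabaeus) for cytotoxicity, read by MTT assay; on this read-out lower numbers stand for higher toxicity in this test and higher numbers for lower toxicity in this test. Compound 1 `Cn1nc(C(F)(F)F)cc1C(=O)Nc1ccc(S(=O)(=O)N2CCCCCCC2)cc1` gives 16000 nM. Compound 2 `Cn1nc(C(F)(F)F)cc1C(=O)Nc1ccc(S(=O)(=O)N2CCOCC2)cc1` gives > 300000 nM, which is a limit of the assay and not a number. Compound 3 `Cn1nc(C(F)(F)F)cc1C(=O)Nc1ccc(S(=O)(=O)N2CCCCC2C(=O)OC(C)(C)C)cc1` gives 38000 nM, the higher of the two actual numbers, and its gap to compound 1 lies beyond the scatter. Compound 4 `Cn1nc(C(F)(F)F)cc1C(=O)Nc1ccc(S(=O)(=O)N2CCCCC2CO)cc1` carries hydroxymethyl in place of tert-butoxycarbonyl on a saturated ring carbon.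

Going by the values given here, only one measured step bears on this change, and it does so loosely. The exchange of one ring for a smaller one on a sulfonyl sulfur gave an at least 18-fold higher number from compound 1 to compound 2 (1.27 log units; beyond the scatter), a large step at a different place in the molecule. On that single precedent, a moderate move towards a higher number is expected in this assay, smaller than that step. The expected change is a 2.1-fold higher number from compound 3 to compound 4 (0.32 log units; beyond the scatter). For compound 4 the estimate is 80000 nM, with an expected range of 25000 nM to 250000 nM.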

Compound 4, half-maximal cytotoxic concentration: 159000 nM
Beside the measured number, compound 4's estimate is 2.0-fold (0.30 log units) below it; low and high end bracket the measured number.
By their numbers in this assay, from the lowest: compound 1; then compound 3; then compound 4. At a limit, above all of these: compound 2.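

On a saturated ring carbon next to the ring nitrogen, hydroxymethyl in place of tert-butoxycarbonyl gives a modest step in this assay: a 4.2-fold higher number from compound 3 to compound 4 (0.62 log units; beyond the scatter). So a change at this ring carbon counts in this test, whereas the earlier step lay in the choice of ring on the sulfonyl sulfur, and the group on the sulfonyl sulfur of compound 4 has the same heavy-atom count as that of compound 1, yet the pair shows a 9.9-fold higher number from compound 1 to compound 4 (1.00 log units; beyond the scatter). Compound 2 stands at a limit and not a number: the limit of > 300000 nM in this assay, at which 1 of the 4 values shown sits. Against that limit the data give only an at least 1.8-fold lower number from compound 2 to compound 4 (0.27 log units; that floor lies within the scatter), so this step cannot be read.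

The compounds shown leave open whether the step follows from hydroxymethyl itself or from the loss of tert-butoxycarbonyl; a methyl group, an amine or a carboxylic acid on this ring carbon would separate the two. They also leave open how hydroxymethyl would read on the eight-membered non-aromatic ring of compound 1.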